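The source may report more compounds than this note shows. Statements on the series, on what has been measured and on what is new or still open speak of the compounds shown alone.

Measured compounds:

Compound 1 `Cn1cc(-c2cnc3ccc(NC(=O)c4ccc(F)cc4)nc3c2)cn1` — in a functional assay on A549 cells (Homo sapiens) for antiproliferative activity, read by MTT assay, with a stated time of 48 h (on this read-out lower numbers stand for stronger inhibition and higher numbers for weaker inhibition), compound 1 gives > 50000 nM, which is a limit of the assay rather than a number.
Compound 2 `Cc1ccc(S(=O)(=O)Nc2ccc3ncc(-c4cnn(C)c4)cc3n2)cc1` — in this assay compound 2 gives 45500 nM.
Compound 3 `Cn1cc(-c2cnc3ccnc(NC(=O)C4CC4)c3c2)cn1` — in this assay compound 3 gives > 50000 nM, again a limit of the assay and not a number.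

Compound 3 therefore stands at the edge of what the assay can report: it shows no measurable inhibition of cell growth, and it shares this position with compound 1, since the limit of > 50000 nM in this assay, at which 2 of the 3 values shown sit, applies to both. Only compound 2 produced an actual number, and that number is itself weak.

Compound 4 `Cn1cc(-c2cnc3ccnc(NC(=O)c4cccnc4)c3c2)cn1` differs from compound 3 in one place: pyridin-3-yl in place of cyclopropyl on a carbonyl carbon. For the measured compounds named here, no measured pair shows this exact change, so the size of its effect cannot be read from the data. Compound 1, which carries an aromatic ring on its amide carbonyl, also sat at the limit, which gives no hint that an aromatic ring at this position brings potency.

The step from compound 3 to compound 4 in this assay is expected to be small or absent, a step that the limit leaves unreadable from compound 3 to compound 4, with compound 4 most likely staying beyond the scatter only in the sense of remaining at the limit. Compound 4 is estimated at 70000 nM, within a range from 20000 nM to 300000 nM.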

Compound 4, half-maximal inhibitory concentration: > 50000 nM
Compound 4: no number, only a limit (the forecaster's own chance of this, stated with the estimate: 65%); the middle value lies beyond the limit too.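

In this assay compound 4 gives > 50000 nM as a limit of the assay and not a number. For the compounds shown here, no step from compound 3 to compound 4 can be read, since both sit at the same limit: the limit of > 50000 nM in this assay, at which 3 of the 4 values shown sit.

From the compounds shown here alone, whether pyridin-3-yl and cyclopropyl on this carbonyl carbon differ at all in this assay stays open.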